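The source may hold more compounds than are shown below. What is called first, only, known or untested is meant among the compounds shown, and "the series" means these compounds.

Measured compounds:
Compound 1 `Cc1cc(C2(c3ccccc3)C(=O)Nc3ccccc32)c(NS(=O)(=O)c2ccc(C(C)(C)C)cc2)cc1O` gives 800 nM in a functional assay on A549 cells (Homo sapiens) for inhibition; on this read-out lower numbers stand for stronger inhibition of growth and higher numbers for weaker inhibition of growth.
Compound 2 `Cc1cc(C2(c3ccccc3)C(=O)Nc3ccccc32)c(NS(=O)(=O)c2ccc(-c3ccccc3)cc2)cc1O` gives 4000 nM in this assay.

Compound 2 carries the higher of the two numbers in this assay; the step of a 5.0-fold higher number from compound 1 to compound 2 (0.70 log units; beyond the scatter) separates it from compound 1 and lies beyond the scatter. Compound 3 `Cc1cc(C2(c3ccccc3)C(=O)Nc3ccccc32)c(NS(=O)(=O)c2ccc(Oc3ccccc3)cc2)cc1O` is not yet measured. It differs from compound 2 by phenoxy in place of phenyl on an aromatic carbon. Among the compounds with values here, no measured step bears directly on this change: the only step in hand, a 5.0-fold higher number from compound 1 to compound 2 (0.70 log units; beyond the scatter), concerns tert-butyl against phenyl on the same aromatic carbon, and says nothing about the oxygen link that phenoxy adds. With both groups carrying one six-membered aromatic ring of carbon only, the step of no change at the digits printed from compound 2 to compound 3 (within the scatter) is expected to stay within the scatter. Compound 3 is therefore estimated at 4000 nM in this assay, with a range from 1500 nM to 12000 nM.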

Compound 3, concentration for 50% growth inhibition: 5000 nM
Beside the measured number, compound 3's estimate is 1.3-fold (0.10 log units) below it; the range from low to high includes it.
By their numbers in this assay, from the lowest: compound 1; then compounds 2 and 3 (each within the scatter of the next).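

In this assay, the oxygen link that phenoxy brings to this aromatic carbon, para to a large group, does not separate compound 3 from compound 2: a 1.3-fold higher number from compound 2 to compound 3 (0.10 log units; within the scatter) is the step between them. Set against tert-butyl, phenoxy gives a 6.3-fold higher number from compound 1 to compound 3 (0.80 log units; beyond the scatter), so both groups that carry a six-membered aromatic ring of carbon only stand apart from compound 1, and the link itself shows no effect beyond the scatter. Nothing in hand explains these numbers.

The compounds shown leave open how an amine or a carboxylic acid at this carbon would read in this assay. They also leave open whether a longer chain between the sulfonyl-bearing ring and the phenyl ring, or a methoxy group on that phenyl ring, would keep the number where compound 2 and compound 3 lie.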